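Side chain exchange on the tetrahydropyranyl purine acetamide

A few compounds are considered here, and "the series" means these few. Any claim that something is new, unique, unknown or untested is made for them only; others in the source may bear on it.

The series shares a purine-derived core carrying a cyclopropyl-bearing acetamide to an amino acid ester. Compound 1 `CC(C)C[C@H](NC(=O)CN(c1nc(Cl)nc2[nH]cnc12)C1CC1)C(=O)OCc1ccccc1`, compound 2 `CSCC[C@H](NC(=O)CN(c1ncnc2c1ncn2C1CCCCO1)C1CC1)C(=O)OCc1ccccc1` and compound 3 `CC(C)C[C@H](NC(=O)CN(c1nc(Cl)nc2[nH]cnc12)C1CC1)C(=O)O` have been tested in a functional assay on the whole organism (Tail, strain ICR) with Mus musculus as the target, in the tail flick test, with a stated time of 60 min, at a dose of 25 umol/kg by the oral route; on this read-out lower numbers stand for a weaker effect and higher numbers for a stronger effect at the one dose given. In this assay compound 1 gives 27.3%, compound 2 gives 41% and compound 3 gives 36.4%. Compound 2 holds the highest of the three numbers; its gap to compound 3 is within the scatter, while its gap to compound 1 lies beyond it, so only the latter separation can be read as real.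

Among the compounds with values here, the one single-point comparison available is a number 9.1 percentage points higher from compound 1 to compound 3 (within the scatter), which is within the scatter and concerns the ester end, not the amino acid side chain.

Compound 4 `O=C(CN(c1ncnc2c1ncn2C1CCCCO1)C1CC1)N[C@@H](CC(=O)OCc1ccccc1)C(=O)OCc1ccccc1` is not yet measured. It differs from compound 2 by benzyloxycarbonyl in place of (methylsulfanyl)methyl on a saturated chain carbon, two bonds along the chain from an amide-type nitrogen and a carbonyl carbon. Within the data shown here, no measured step touches this side-chain position, so nothing in the data points to a direction. Compound 4 is expected to give about 35%, with a range from 15% to 55%. The expected step of a number 6 percentage points lower from compound 2 to compound 4 (within the scatter) is therefore taken as none beyond the scatter, with wide uncertainty.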

Compound 4, a percentage reported as activity, at one dose (the size of the read-out at that dose, not a potency): 38.2%
The estimate for compound 4 lay 3.2 percentage points below the measured number; measured number inside the range.
By their numbers in this assay, from the lowest: compounds 1, 3, 4 and 2 (each within the scatter of the next, the first and the last beyond it).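

Side-chain position, working notes: replacing (methylsulfanyl)methyl with benzyloxycarbonyl on a saturated chain carbon, two bonds along the chain from an amide-type nitrogen and a carbonyl carbon, reads in this assay as a number 2.8 percentage points lower from compound 2 to compound 4 (within the scatter) and gives the only measured step at this position. The earlier step concerned the ester end, whereas this one shows that, on the core of compound 2, a group of 10 heavy atoms with a six-membered aromatic ring can replace a group of 3 heavy atoms containing sulfur without a difference beyond the scatter. No supporting measurement bears on why the read-out stays within the scatter across this exchange.

As far as these compounds go, a single exchange does not define the tolerance of this position, so a free carboxylic acid in place of benzyloxycarbonyl, a primary amine, or a longer alkyl chain on the same carbon remains open. Also open, from the compounds shown here alone, is whether the same exchange would stay within the scatter at other doses or times, since the read-out covers a single dose and a single stated time.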